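A few compounds are considered here, and "the series" means these few. Any claim that something is new, unique, unknown or untested is made for them only; others in the source may bear on it.

Working notes on the series. In a functional assay on IMR-32 cells for inhibition of Voltage-dependent N-type calcium channel subunit alpha-1B (Homo sapiens), read by calcium flux (a higher number here means a weaker inhibitor, a lower number a stronger inhibitor), compound 3 `CC1=NC(C)=C(C(=O)O)C(c2cccc(Cl)c2)/C1=C(\O)OC/C(C)=C/c1ccccc1` gives 680 nM, the lowest of the three numbers shown, though within the scatter of both others. Compound 1 `CC1=NC(C)=C(C(=O)O)C(c2cccc(Cl)c2)/C1=C(\O)OC/C=C/C1CCCCC1` gives 830 nM in this assay, and compound 2 `CC1=NC(C)=C(C(=O)O)C(c2cccc(Cl)c2)/C1=C(\O)OC/C=C/c1ccc(C)cc1` gives 890 nM. None of the gaps among the three is a step beyond the scatter: a 1.2-fold lower number from compound 1 to compound 3 (0.09 log units; within the scatter), a 1.3-fold lower number from compound 2 to compound 3 (0.12 log units; within the scatter), and a 1.1-fold higher number from compound 1 to compound 2 (0.03 log units; within the scatter). All three share the core and differ only in the group on the saturated chain carbon bound to an oxygen on an unsaturated carbon, so exchanging 2-cyclohexylethenyl, 2-(4-methylphenyl)ethenyl and 1-methyl-2-phenylethenyl there leaves the number within the scatter.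

Compound 4 `CC1=NC(C)=C(C(=O)O)C(c2cccc(Cl)c2)/C1=C(\O)OCc1ccc2ccccc2c1` extends the set: naphthalen-2-yl in place of 1-methyl-2-phenylethenyl on a saturated chain carbon bound to an oxygen on an unsaturated carbon. The double bond outside aromatic rings is gone and a second six-membered aromatic ring of carbon only appears, a larger departure than any within the measured trio. For the measured compounds named here, the steps that bear on it are those at the same position, a 1.2-fold lower number from compound 1 to compound 3 (0.09 log units; within the scatter) and a 1.3-fold lower number from compound 2 to compound 3 (0.12 log units; within the scatter), and the swap on the double-bonded chain carbon, a 1.1-fold higher number from compound 1 to compound 2 (0.03 log units; within the scatter), all within the scatter. The expected step is accordingly a 1.0-fold higher number from compound 3 to compound 4 (0.01 log units; within the scatter), no change beyond the scatter in either direction. Compound 4 is estimated at 700 nM in this assay, with a range of 280 nM to 1800 nM. Going by the values given here, no measured compound carries a group of this kind, and the range is kept wide.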

Compound 4, half-maximal inhibitory concentration: 1000 nM
For compound 4 the middle estimate is 1.4-fold (0.15 log units) below the measured one; the range from low to high includes it.
By their numbers in this assay, from the lowest: compounds 3, 1, 2 and 4 (each within the scatter of the next).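

For the compounds shown here, on the saturated chain carbon bound to an oxygen on an unsaturated carbon, naphthalen-2-yl in place of 1-methyl-2-phenylethenyl gives, in this assay, a 1.5-fold higher number from compound 3 to compound 4 (0.17 log units; within the scatter), so this position also accepts a group with 2 six-membered aromatic rings of carbon only and no double bond outside aromatic rings, a kind of group absent from the earlier compounds. The comparisons with the other two groups agree, with a 1.1-fold higher number from compound 2 to compound 4 (0.05 log units; within the scatter) and a 1.2-fold higher number from compound 1 to compound 4 (0.08 log units; within the scatter), so across these four compounds the double bond outside aromatic rings is not needed to keep the number within the scatter. No measurement is available here that explains why the number stays so flat across these groups.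

As far as these compounds go, all four groups consist of carbon and hydrogen only, so it remains open whether an amine, a carboxylic acid or a hydroxyl group at this position would produce a step beyond the scatter. Also open, from the compounds shown here alone, is what a longer chain carrying the naphthalen-2-yl group, or naphthalen-1-yl in its place, would do to the number.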